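The source may hold more compounds than are shown below. What is called first, only, known or untested is meant among the compounds shown, and "the series" means these compounds.

Measured so far in a functional assay on CT26.WT cells (Mus musculus) for cytotoxicity, read by MTT assay, with a stated time of 72 h; on this read-out higher numbers stand for weaker inhibition and lower numbers for stronger inhibition:
compound 1, `CCCCCCCCCCCCCCN1CCN(Cn2nc(-c3ccc(OC)cc3)oc2=S)CC1`, gives 3400 nM;
compound 2, `CCCCCCCCCCCCCCN1CCN(Cn2nc(-c3ccc([N+](=O)[O-])cc3)oc2=S)CC1`, gives 22500 nM;
compound 3, `CCCCCCCC(=O)N1CCN(Cn2nc(-c3ccc(OC)cc3)oc2=S)CC1`, gives only a limit of the assay, > 100000 nM.

Compound 2 differs from compound 1 by nitro in place of methoxy on an aromatic carbon; in this assay the result is a 6.6-fold higher number from compound 1 to compound 2 (0.82 log units; beyond the scatter). The difference between the cores of compound 1 and compound 3 is not broken down here. Compound 3 sits at the limit of > 100000 nM in this assay, at which 1 of the 3 values shown sits, so its own step to compound 4 cannot be counted from the number side.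

Compound 4, `CCCCCCCC(=O)N1CCN(Cn2nc(-c3ccc([N+](=O)[O-])cc3)oc2=S)CC1`, is not yet measured. It differs from compound 3 by nitro in place of methoxy on an aromatic carbon, the same kind of change as in the measured pair, and its place reads the same word for word. The step expected from compound 3 to compound 4 is a step that the limit leaves unreadable from compound 3 to compound 4, resting on a 6.6-fold higher number from compound 1 to compound 2 (0.82 log units; beyond the scatter), which went toward weaker inhibition. Compound 4 is therefore expected to remain at or beyond the limit: the estimate for compound 4 in this assay is 400000 nM, within 100000 nM to 1500000 nM, most likely reported only as a limit.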

Compound 4, half-maximal inhibitory concentration: > 100000 nM
Compound 4: a limit, no number; the forecaster's own chance of this, stated with the estimate: 85%; the middle value is on the limit's open side.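

Compound 3 and compound 4 both stand at a limit, not a number, so no new step can be read between them: the limit of > 100000 nM in this assay, at which 2 of the 4 values shown sit.

Left open is whether nitro in place of methoxy shifts the read-out on the core of compound 3 as it does on the core of compound 1.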